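Methoxymethoxy in place of methoxy in the dimethoxy compound

This account rests on a few compounds, and the source may have more. Where it says the series, first, only, none or still open, it means among the compounds named here.

Measured so far in a functional assay on KM12 cells (Homo sapiens) for antiproliferative activity (a higher number here means a weaker inhibitor of growth, a lower number a stronger inhibitor of growth), for three compounds:
- compound 1 `COc1ccc(-c2nc3cc(F)ccc3s2)cc1Cl` gives 7050 nM
- compound 2 `COc1ccc(-c2nc3cc(F)ccc3s2)cc1OC` gives 290 nM
- compound 3 `COc1cc(-c2nc3cc(F)ccc3s2)cc(OC)c1OC` gives 13000 nM

Compound 2 holds the lowest of the three numbers. Compound 4 `COCOc1ccc(-c2nc3cc(F)ccc3s2)cc1OC` departs from it by one change: methoxy in place of hydrogen on a saturated chain carbon bound to an oxygen on an aromatic ring that is, methoxy in place of hydrogen on a saturated chain carbon bound to an oxygen on an aromatic ring, or methoxy to methoxymethoxy. For the measured compounds named here, no measured step touches that chain, so the two available steps bear on it only loosely. Methoxy in place of chloro gave a 24-fold lower number from compound 1 to compound 2 (1.39 log units; beyond the scatter) and methoxy in place of hydrogen on an aromatic carbon gave a 45-fold higher number from compound 2 to compound 3 (1.65 log units; beyond the scatter) and both are large. Going by the values given here, since compound 3 stands at 13000 nM after the one measured addition to compound 2, a higher number is expected here, though probably a smaller move. Among the compounds with values here, the only precedent is on an aromatic carbon. The expected step is a 4.1-fold higher number from compound 2 to compound 4 (0.62 log units; beyond the scatter) with wide uncertainty. For compound 4 the estimated value is 1200 nM with an expected range from 200 nM to 8000 nM on this reading.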

Compound 4, concentration for 50% growth inhibition: 19300 nM
For compound 4 the middle estimate is 16-fold (1.21 log units) below the measured one; measured number outside the range, above it.
By their numbers in this assay, from the lowest: compound 2; then compounds 1, 3 and 4 (each within the scatter of the next, the first and the last beyond it).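

In this assay, going from methoxy to methoxymethoxy gives a 67-fold higher number from compound 2 to compound 4 (1.82 log units; beyond the scatter), so this change on a saturated chain carbon bound to an oxygen on an aromatic ring is not tolerated in this series. The earlier steps shown here showed changes on aromatic carbons only; this one shows that extending the methoxy group itself also carries a large penalty, leaving compound 2 with the lowest number of the series. Nothing given here accounts for the size of this step.

As far as these compounds go, whether the step follows from the added oxygen or simply from the longer chain stays open, and an ethoxy or propoxy group in the same place would separate the two. Also open, from the compounds shown here alone, is whether the other methoxy group of compound 2 responds in the same way to this extension.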